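Shifting One Hydroxyl Group on a Shared Core

This account rests on a few compounds, and the source may have more. Where it says the series, first, only, none or still open, it means among the compounds named here.

compound 1 `Oc1ccc(-c2cc(-c3ccc(C(F)(F)F)cc3)cc(-c3ccc(O)cc3)n2)cc1`: > 50000 nM in a functional assay on HeLa cells (Homo sapiens) for inhibition; on this read-out higher numbers stand for weaker inhibition and lower numbers for stronger inhibition
compound 2 `Oc1ccc(-c2cc(-c3ccc(OC(F)(F)F)cc3)cc(-c3ccccc3O)n2)cc1`: > 50000 nM in this assay
compound 3 `Oc1ccc(-c2cc(-c3ccc(OC(F)(F)F)cc3)cc(-c3cccc(O)c3)n2)cc1`: 27800 nM in this assay

The values of compound 1 and compound 2 are limits of the assay, not numbers, as the limit of > 50000 nM in this assay, at which 2 of the 3 values shown sit, records. Within the data shown here, compound 3 thus stands as the only measured number among the three. Among the measured compounds shown here, the only measured step is an at least 1.7-fold lower number from compound 2 to compound 3 (0.25 log units; that floor lies within the scatter), whose floor lies within the scatter. Compound 4 `Oc1ccc(-c2cc(-c3ccc(OC(F)(F)F)cc3)cc(-c3ccc(O)cc3)n2)cc1` differs from compound 3 by 4-hydroxyphenyl in place of 3-hydroxyphenyl on an aromatic carbon. For the measured compounds named here, no measured step covers this exact change. Compound 1, which also carries two 4-hydroxyphenyl groups, gives only a limit in this assay. Compound 4 is therefore expected to give 60000 nM (range 20000 nM to 200000 nM), an expected step of a 2.2-fold higher number from compound 3 to compound 4 (0.33 log units; beyond the scatter) toward weaker inhibition, most likely reported as a limit.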

Compound 4, half-maximal inhibitory concentration: 16900 nM
Compound 4: middle estimate off by 3.6-fold (0.55 log units), on the high side, outside the stated range (below it).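

Replacing 3-hydroxyphenyl with 4-hydroxyphenyl at this position gives a 1.6-fold lower number from compound 3 to compound 4 (0.22 log units; within the scatter), so in this assay these two hydroxyl placements cannot be told apart. The 2-hydroxyphenyl placement can now be separated from the 4-hydroxyphenyl one, with 4-hydroxyphenyl in its place giving an at least 2.9-fold lower number from compound 2 to compound 4 (0.47 log units; beyond the scatter). Elsewhere on the shared core, trifluoromethoxy in place of trifluoromethyl gives an at least 2.9-fold lower number from compound 1 to compound 4 (0.47 log units; beyond the scatter), and both of these larger steps are only floors: the limit of > 50000 nM in this assay, at which 2 of the 4 values shown sit.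

Open, from the compounds shown here alone, is whether an amine or a carboxylic acid in place of the hydroxyl on the 4-hydroxyphenyl group would strengthen inhibition or weaken it.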